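A few compounds are considered here, and "the series" means these few. Any claim that something is new, unique, unknown or untested is made for them only; others in the source may bear on it.

Compound 1 `CCN(CC)C(=O)Nc1ccc2[nH]ccc2c1` and compound 2 `CCN(CC)C(=O)Oc1ccc2cc[nH]c2c1` share a common core. In an assay on isolated protein for inhibition of Amine oxidase [flavin-containing] B (Homo sapiens), read by fluorescence, with stated times of 10 min, 10 s and 20 min (on this read-out lower numbers stand for stronger inhibition and higher numbers for weaker inhibition), compound 1 returns only a limit, > 100000 nM, not a number. Compound 2 likewise returns only a limit in this assay, > 100000 nM. Both values sit at the limit of > 100000 nM in this assay, at which 2 of the 2 values shown sit, so no numbered potency exists for either. Compound 3 `C#CCn1ccc2ccc(OC(=O)N(CC)CC)cc21` differs from compound 2 by propargyl in place of hydrogen on an aromatic nitrogen. For the measured compounds named here, no measured step covers this change, so the expectation rests on the limit and the change alone. A move toward stronger inhibition beyond the usual scatter is expected from compound 2 to compound 3, an at least 10-fold lower number from compound 2 to compound 3 (1.00 log units; beyond the scatter). Compound 3 is therefore estimated at 10000 nM, within a range from 1000 nM to 100000 nM.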

Compound 3, half-maximal inhibitory concentration: 1840 nM
Estimate against measurement, compound 3: 5.4-fold (0.74 log units) above; low and high end bracket the measured number.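

Propargyl in place of hydrogen on the aromatic nitrogen gives the only numbered potency shown in this assay, with an at least 54-fold lower number from compound 2 to compound 3 (1.73 log units; beyond the scatter) (large), so a change at this position can bring measurable inhibition. That step is only a minimum, because compound 2 stands at a limit and not at a number: the limit of > 100000 nM in this assay, at which 2 of the 3 values shown sit.

Still open, on these data alone, is whether a plain propyl or methyl group on the same nitrogen would do the same, which would show whether the triple bond matters. Also open, as far as these compounds go, is whether propargyl would bring a similar gain to compound 1.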